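Trimming a heteroaromatic ring down to a methoxy group

The source may hold more compounds than are shown below. What is called first, only, known or untested is meant among the compounds shown, and "the series" means these compounds.

Measured so far:
Compound 1, `Cc1c(OCC2=NCCN2)ccc(Cl)c1NS(C)(=O)=O`: 25 nM
Compound 2, `Cc1oncc1-c1cccc2c1CCC2c1ncc[nH]1`: 111 nM
Compound 3, `CS(=O)(=O)Nc1cccc2c1CCCC2c1ncc[nH]1`: 2150 nM; 142 nM; 234 nM (3 entries)

All three compounds were tested in a functional assay on CHO cells for agonist activity at Alpha-1A adrenergic receptor (Homo sapiens), read by FLIPR and calcium flux; a lower number here means that less compound is needed, a higher number that more compound is needed for the effect. Compound 2 holds the higher of the two single numbers; compound 1 gives a lower number, and that gap lies beyond the usual scatter. Compound 3 cannot be placed on a single number: its repeated entries the several entries of compound 3 in this assay, 2150 nM; 142 nM; 234 nM (3 entries) spread widely, so it gives only a rough sense of where a compound of this kind may land.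

The next compound, compound 4, is `COc1cccc2c1CCC2c1ncc[nH]1`. It keeps the shared core of compound 2 and changes one substituent: methoxy in place of 5-methyl-1,2-oxazol-4-yl on an aromatic carbon. Among the measured compounds shown here, no pair of measured compounds shows this exact change, so its effect must be guessed. Among the measured compounds, the larger ring substituent of compound 2 sits with the lower single number, while compound 3, which carries a small polar group on a related core, returns mostly higher numbers. A modest rise in the number, possibly beyond the scatter, seems the most likely outcome. Compound 4 is expected to give 300 nM, with a range from 80 nM to 1500 nM. The step expected here is a 2.7-fold higher number from compound 2 to compound 4 (0.43 log units; beyond the scatter).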

Compound 4, half-maximal effective concentration: 32 nM
Compound 4: the middle estimate sits 9.4-fold (0.97 log units) above what was measured; the measured number lies below the stated range.
By their numbers in this assay, from the lowest: compounds 1 and 4 (each within the scatter of the next); then compound 2.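

In this assay, methoxy in place of 5-methyl-1,2-oxazol-4-yl on an aromatic carbon, ortho to a fused ring, gives a 3.5-fold lower number from compound 2 to compound 4 (0.54 log units; beyond the scatter) and so shows that this position tolerates a much smaller substituent. Among the compounds shown here, the five-membered aromatic ring of 6 heavy atoms is therefore not required here for agonist activity, since a group of 2 heavy atoms with no ring needs less compound for the effect, although this rests on a single pair of compounds on one shared core. The data shown offer no measurement that explains why this exchange lowers the number.

Going by these compounds, it remains open whether the lower number belongs to methoxy specifically or would come with almost any small group at this position, a question that a plain hydrogen, a hydroxy group, a chlorine atom or a longer ethoxy chain at the same carbon could help to settle. For the compounds shown here, it is also open whether the same exchange would have a similar effect on a different core, since only this one core provides a comparison.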